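The compounds below may be only part of what the source reports. "The series", "measured", "known", "first", "only" and "open" are said of these compounds alone.

Measured in a physicochemical assay for solubility, in phosphate buffer; on this read-out lower numbers stand for lower solubility and higher numbers for higher solubility:
- compound 1 `C[C@H](CO)N1C[C@H](C)[C@@H](CN(C)Cc2ccc(Oc3ccccc3)cc2)Oc2c(NC(=O)c3ccncc3)cccc2C1=O`: 2000 nM
- compound 2 `C[C@@H]1CN([C@H](C)CO)C(=O)c2cccc(NC(=O)c3ccncc3)c2O[C@@H]1CN(C)Cc1ccc(Oc2ccccc2)cc1`: 86000 nM

For the measured compounds named here, compound 2, at 86000 nM, holds the higher of the two numbers so far. Next is compound 3 `C[C@@H]1CN([C@H](C)CO)C(=O)c2cccc(NC(=O)c3ccncc3)c2O[C@H]1CN(C)Cc1ccc(Oc2ccccc2)cc1`, with nothing leaving and nothing entering: the two compounds have the same atoms and bonds and differ only in configuration as drawn: 1 of 3 stereo elements differ; a stereocentre at a saturated ring carbon is drawn S in compound 2 and R in compound 3.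

Going by the values given here, one measured step bears on this change: a 43-fold higher number from compound 1 to compound 2 (1.63 log units; beyond the scatter). It is large, and it rests on (the fact that compounds 1 and 2 differ only in the configuration as drawn). In that pair, then, a single change of configuration moved the read-out far, but one step gives no direction for a new change. With compound 2 at 86000 nM, the top of the range seen so far, a fall in this assay beyond the scatter is expected, though smaller than the measured step. The expected change is a 4.3-fold lower number from compound 2 to compound 3 (0.63 log units; beyond the scatter). The estimate for compound 3 is 20000 nM, with an expected range of 3000 nM to 100000 nM.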

Compound 3, solubility: 1000 nM
Beside the measured number, compound 3's estimate is 20-fold (1.30 log units) above it, and the stated range ends above it.
By their numbers in this assay, from the lowest: compounds 3 and 1 (each within the scatter of the next); then compound 2.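

In this assay, a second stereocentre at a saturated ring carbon proves as decisive as the first, with an 86-fold lower number from compound 2 to compound 3 (1.93 log units; beyond the scatter), so the read-out responds strongly at two separate ring positions rather than one. Inverting both centres gives only a 2.0-fold lower number from compound 1 to compound 3 (0.30 log units; within the scatter), which places compound 2 alone at the high end of these three stereoisomers, and each single inversion connecting it to the others gives a large step. The large step can be attributed to configuration alone because the connectivity is unchanged: the fact that compounds 2 and 3 differ only in the configuration as drawn

The compounds shown leave open how the fourth combination of these two ring centres behaves, and what inverting the third stereo element would do. From the compounds shown here alone, it is also open whether the high number of compound 2 would hold with a carboxylic acid on the shared core.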